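Trimming the Tail of Compound 1 to a Plain Benzamide

The source may hold more compounds than are shown below. What is called first, only, known or untested is meant among the compounds shown, and "the series" means these compounds.

Within the data shown here, compound 1 `COc1cc(-c2nn(-c3cccc(NC(=O)Nc4ccc(Cl)c(Cl)c4)c3)cc2-c2ccncc2)ccc1Cl` is one of three compounds measured in a functional assay on SK-MEL-5 cells (Homo sapiens) for inhibition, read by sulforhodamine B assay, with a stated time of 48 h (a higher number here means a weaker inhibitor of growth, a lower number a stronger inhibitor of growth), and compound 1 gives 1490 nM, the highest of the three numbers, though all three sit within the usual scatter of one another. Compound 2 `O=C(Nc1cccc(-n2cc(-c3ccncc3)c(-c3ccc(Cl)c(O)c3)n2)c1)Nc1ccc(Cl)c(Cl)c1` gives 1160 nM in this assay, and compound 3 `O=C(Nc1cccc(-n2cc(-c3ccncc3)c(-c3ccc(Cl)c(O)c3)n2)c1)Nc1cc(C(F)(F)F)cc(C(F)(F)F)c1` gives 1250 nM. Among the measured compounds shown here, the one step that can be followed directly, a 1.3-fold lower number from compound 1 to compound 2 (0.11 log units; within the scatter), shows that exchanging the methyl on the aromatic oxygen for hydrogen leaves the growth inhibition essentially unchanged; compound 2 and compound 3, which differ in the aryl group on the far nitrogen, also return numbers that lie together.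

Compound 4 `COc1cc(-c2nn(-c3cccc(NC(=O)c4ccccc4)c3)cc2-c2ccncc2)ccc1Cl` has not been measured. It differs from compound 1 by phenyl in place of (3,4-dichlorophenyl)amino on a carbonyl carbon. For the measured compounds named here, no measured pair maps this change: the aryl groups swapped between compound 2 and compound 3 kept the nitrogen and its hydrogen in place, whereas here the amino link itself is lost together with both chlorines. With nothing in the series speaking for a gain, compound 4 is expected to sit near or somewhat above compound 1, a step of a 2.0-fold higher number from compound 1 to compound 4 (0.30 log units; within the scatter). Compound 4 is therefore estimated at 3000 nM, with a range from 1000 nM to 10000 nM.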

Compound 4, concentration for total growth inhibition: 1380 nM
For compound 4 the middle estimate is 2.2-fold (0.34 log units) above the measured one, and the stated range covers the measured number.
By their numbers in this assay, from the lowest: compounds 2, 3, 4 and 1 (each within the scatter of the next).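

At the carbonyl carbon of compound 1, phenyl in place of (3,4-dichlorophenyl)amino gives a 1.1-fold lower number from compound 1 to compound 4 (0.03 log units; within the scatter) in this assay, so the cut from ((3,4-dichlorophenyl)carbamoyl)amino to benzamido leaves the number within the scatter. The earlier compounds shown here changed the group on the aromatic oxygen or the aryl group on the far nitrogen while the amino link stayed in place; this pair shows that, with the rest of compound 1 unchanged, the link and the chlorines can go together without a change beyond the scatter in this growth read-out. Nothing available explains why the number holds, and no supporting measurement bears on this result.

The compounds shown leave open whether the same holds when the phenyl of compound 4 carries a substituent such as a dimethylamino group, a carboxylic acid or a morpholine, or when a sulfonamide takes the place of the benzamido group. They also leave open whether the same cut behaves alike on compound 2, whose aromatic oxygen carries hydrogen rather than methyl.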